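Fluorophenylpiperazine series: moving fluorine on the aryl ring

The source may hold more compounds than are shown below. What is called first, only, known or untested is meant among the compounds shown, and "the series" means these compounds.

In an assay on HEK293 cells for inhibition of Voltage-dependent T-type calcium channel subunit alpha-1G (Homo sapiens), read by fluorescence, tested at 10 uM (a higher number here means more inhibition at the concentration tested (going by the name of the read-out), a lower number less inhibition), compound 1 `CCCc1nc(-c2ccccc2)c(CNCCN2CCN(c3ccc(F)cc3)CC2)o1` gives 54.1%, the lowest of the three values recorded. Compound 2 `CCCc1nc(-c2ccccc2)c(CNCCCN2CCN(c3ccccc3Cl)CC2)o1` gives 64.7% and compound 3 `CCCc1nc(-c2ccccc2)c(CNCCN2CCN(C(c3ccccc3)c3ccccc3)CC2)o1` gives 71.9%, both above compound 1 by more than the usual scatter. For the measured compounds named here, no two measured compounds differ in only one place, so no single structural step is isolated among them. Compound 4 `CCCc1nc(-c2ccccc2)c(CNCCN2CCN(c3cccc(F)c3)CC2)o1` differs from compound 1 in one place: 3-fluorophenyl in place of 4-fluorophenyl on an amine nitrogen in a ring. Going by the values given here, no measured pair tests this change, so the expected step of a number 0.9 percentage points higher from compound 1 to compound 4 (within the scatter) is taken to be small, not beyond the scatter in either direction. Compound 4 is therefore expected to give about 55% in this assay, with a range from 40% to 70%.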

Compound 4, a percentage reported as inhibition, at one concentration (the size of the read-out at that concentration, not a potency): 62.3%
For compound 4 the middle estimate is 7.3 percentage points below the measured one; low and high end bracket the measured number.
By their numbers in this assay, from the lowest: compounds 1, 4, 2 and 3 (each within the scatter of the next, the first and the last beyond it).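

In this assay the series gains its first comparison that differs in one place: a number 8.2 percentage points higher from compound 1 to compound 4 (within the scatter). At this position on the ring nitrogen, 3-fluorophenyl and 4-fluorophenyl therefore cannot be told apart at the single concentration tested. Nothing at hand bears on the origin of this step. Open, as far as these compounds go, is how a nitrile or a methoxy group in place of the fluorine of compound 4 would read. Also open, from the compounds shown here alone, is whether the 3-fluorophenyl group would read the same way on a longer chain.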